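Dropping one trifluoromethyl from a urea-linked pyrazole series

A few compounds are considered here, and "the series" means these few. Any claim that something is new, unique, unknown or untested is made for them only; others in the source may bear on it.

Measured compounds:
Compound 1, `COc1cc(Cl)cc(-c2nn(-c3cccc(NC(=O)Nc4ccc(Cl)c(C(F)(F)F)c4)c3)cc2-c2ccncc2)c1`, gives 50% in a functional assay on MDA-MB-468 cells (Homo sapiens) for inhibition, read by sulforhodamine B assay, with a stated time of 48 h, tested at 1 uM; on this read-out higher numbers stand for a weaker effect at the one concentration tested and lower numbers for a stronger effect.
Compound 2, `COc1cc(Cl)cc(-c2nn(-c3cccc(NC(=O)Nc4cc(C(F)(F)F)cc(C(F)(F)F)c4)c3)cc2-c2ccncc2)c1`, gives 15% in this assay.

Both compounds share the same core and differ only in the substituted ring at the far end of the urea. Compound 2 stands at the lower of the two numbers, and since lower means a stronger effect here, it shows the stronger inhibition of the pair; the gap to compound 1 is beyond the usual scatter, so the difference between them is real.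

Compound 3, `COc1cc(Cl)cc(-c2nn(-c3cccc(NC(=O)Nc4cccc(C(F)(F)F)c4)c3)cc2-c2ccncc2)c1`, has not yet been measured in this assay. It derives from compound 2 by a single change: hydrogen in place of trifluoromethyl on an aromatic carbon. The remaining ring of compound 3 therefore carries one trifluoromethyl only.

Going by the values given here, no step between measured compounds matches this change, so the expectation rests on the two values alone. Compound 2, with two trifluoromethyl groups, gives 15%, and removing one of them is expected to weaken the effect, giving an upward step from compound 2 to compound 3 of about a number 25 percentage points higher from compound 2 to compound 3 (beyond the scatter). For compound 3 the expected value is 40%, with a likely range from 20% to 65%.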

Compound 3, a percentage reported as activity, at one concentration (the size of the read-out at that concentration, not a potency): 51%
Compound 3: the middle estimate sits 11 percentage points below what was measured; the range from low to high includes it.
By their numbers in this assay, from the lowest: compound 2; then compounds 1 and 3 (each within the scatter of the next).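

In this assay, the second trifluoromethyl of compound 2, on the aromatic carbon meta to a large group and meta to a trifluoromethyl group, clearly counts: hydrogen in its place gives a number 36 percentage points higher from compound 2 to compound 3 (beyond the scatter) and so a much weaker effect at the one concentration tested. The chloro of compound 1 sits on a different carbon of the same ring, and hydrogen in place of it gives a number 1 percentage points higher from compound 1 to compound 3 (within the scatter) and thus no difference that can be told from the usual scatter, so the two substituents do not carry equal weight in this small set. Nothing measured here explains why the trifluoromethyl matters so much at its carbon.

The compounds shown leave open whether trifluoromethyl itself is needed at this carbon or whether another group, such as a methyl, a methoxy, a nitrile or a single fluorine, would restore the effect seen with compound 2. They also leave open whether these differences at a single concentration would hold across a full range of concentrations.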